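Replacing Naphthalen-1-yl with 4-Chlorophenyl: Expected Growth Inhibition

This account rests on a few compounds, and the source may have more. Where it says the series, first, only, none or still open, it means among the compounds named here.

Compound 1 `COc1cc(C2CC(c3ccc([N+](=O)[O-])cc3)=NN2C(C)=O)ccc1OCc1cn(Cc2ccc([N+](=O)[O-])cc2)nn1` gives 39%
Compound 2 `COc1cc(C2CC(c3ccccc3)=NN2C(C)=O)ccc1OCc1cn(Cc2ccc([N+](=O)[O-])cc2)nn1` gives 0%
Compound 3 `COc1cc(C2CC(c3cccc4ccccc34)=NN2C(C)=O)ccc1OCc1cn(Cc2ccc([N+](=O)[O-])cc2)nn1` gives 89%

In a functional assay on A549 cells (Homo sapiens) for inhibition, read by sulforhodamine B assay, tested at 10 uM (on this read-out higher numbers stand for more inhibition of growth at the one concentration tested and lower numbers for less inhibition of growth), compound 3 stands highest of the three measured compounds: a number 50 percentage points higher from compound 1 to compound 3 (beyond the scatter) and a number 89 percentage points higher from compound 2 to compound 3 (beyond the scatter). Compound 4 `COc1cc(C2CC(c3ccc(Cl)cc3)=NN2C(C)=O)ccc1OCc1cn(Cc2ccc([N+](=O)[O-])cc2)nn1` differs from compound 3 by 4-chlorophenyl in place of naphthalen-1-yl on a carbon with a double bond to nitrogen. Within the data shown here, two measured steps bear on this change, both large: a number 89 percentage points higher from compound 2 to compound 3 (beyond the scatter), where phenyl became naphthalen-1-yl, and a number 50 percentage points higher from compound 1 to compound 3 (beyond the scatter), where 4-nitrophenyl became naphthalen-1-yl. Compound 4 lacks the naphthalen-1-yl again, and 4-chlorophenyl is not among the groups measured, so a large drop is expected, a number 54 percentage points lower from compound 3 to compound 4 (beyond the scatter). Compound 4 is therefore estimated at 35%, in a range from 5% to 70%.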

Compound 4, percent growth inhibition at one concentration: 0%
Beside the measured number, compound 4's estimate is 35 percentage points above it, outside the stated range (below it).
By their numbers in this assay, from the lowest: compounds 2 and 4 (each within the scatter of the next); then compound 1; then compound 3.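

In this assay, 4-chlorophenyl does not carry the growth inhibition of naphthalen-1-yl on this carbon, with a number 89 percentage points lower from compound 3 to compound 4 (beyond the scatter). On the aromatic carbon, chloro in place of hydrogen gives no change at the digits printed from compound 2 to compound 4 (within the scatter), whereas chloro in place of nitro gives a number 39 percentage points lower from compound 1 to compound 4 (beyond the scatter), so among the single-ring groups shown only 4-nitrophenyl gives measurable inhibition. Nothing available explains this difference between chloro and nitro. The compounds shown leave open whether naphthalen-2-yl would match naphthalen-1-yl on this carbon, and whether 4-aminophenyl or 4-methoxyphenyl would behave like 4-nitrophenyl or like 4-chlorophenyl.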